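The source may hold more compounds than are shown below. What is called first, only, known or untested is meant among the compounds shown, and "the series" means these compounds.

Working notes on the series built on the shared core of compound 1 `Cc1cc(C(N)=O)nn1Cc1cc(Cl)ccc1OCc1ccccc1`, which in a physicochemical assay for lipophilicity, at pH 7.4 (on this read-out lower numbers stand for lower lipophilicity and higher numbers for higher lipophilicity), gives 3.7. Compound 2 `Cc1cc(C(=O)NCc2ccccc2)nn1Cc1cc(Cl)ccc1OCc1ccccc1` carries benzyl in place of hydrogen on an amide-type nitrogen; in this assay compound 2 reports only a limit, > 3.7. Compound 3 `Cc1cc(NC(=O)C(C)C)nn1Cc1cc(Cl)ccc1OCc1ccccc1` carries (isopropylcarbonyl)amino in place of carbamoyl on an aromatic carbon; in this assay compound 3 likewise reports only a limit, > 3.7. The steps of a number no lower from compound 1 to compound 2 (the limit leaves the size open) and a number no lower from compound 1 to compound 3 (the limit leaves the size open) are thus open upward, and the step that the two limits leave unreadable from compound 2 to compound 3 cannot be read at all, since (the limit of > 3.7 in this assay, at which 2 of the 3 values shown sit). Compound 3 therefore stands at the upper edge of what the numbers show, with no number of its own.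

Compound 4 `Cc1cc(NC(=O)OCC(C)C)nn1Cc1cc(Cl)ccc1OCc1ccccc1` differs from compound 3 by isobutoxy in place of isopropyl on a carbonyl carbon. Among the measured compounds shown here, no measured step alters the group on a carbonyl carbon, so none bears directly on this change; the measured steps only show that compound 3 and compound 2 reach the limit. For compound 4 the expectation is a step that the limit leaves unreadable from compound 3 to compound 4 in this assay, most likely again reported as a limit, with the estimate 4.2 between 3.7 and 4.8.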

Compound 4, distribution coefficient: 3.3
Beside the measured number, compound 4's estimate is 0.90 log units above it; measured number outside the range, below it.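

The group on this carbonyl carbon now has a readable effect: in this assay, isobutoxy in place of isopropyl gives a number at least 0.40 log units lower from compound 3 to compound 4 (beyond the scatter). The wider comparisons on the aromatic carbon point the same way, with (isobutoxycarbonyl)amino in place of benzylcarbamoyl giving a number at least 0.40 log units lower from compound 2 to compound 4 (beyond the scatter) and in place of carbamoyl giving a number 0.40 log units lower from compound 1 to compound 4 (beyond the scatter), which makes (isobutoxycarbonyl)amino the lowest of the groups shown at this position. Compound 2 and compound 3 report only limits, so the two steps from them give a minimum and not a full size: the limit of > 3.7 in this assay, at which 2 of the 4 values shown sit.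

The compounds shown do not separate the oxygen of isobutoxy from its carbon chain, a question that isobutyl or methoxy on the same carbonyl carbon would address. From the compounds shown here alone, whether an amine or a carboxylic acid at this position would follow the same direction also stays open.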